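Adding a Methyl to the Pendant Phenyl of Compound 3

A few compounds are considered here, and "the series" means these few. Any claim that something is new, unique, unknown or untested is made for them only; others in the source may bear on it.

Compound 1 `Cc1ccccc1-c1c(C(=O)N(C)Cc2ccccc2Cl)n(C)c(=O)c2ccccc12`: 19 nM
Compound 2 `CN(Cc1cc(C(F)(F)F)cc(C(F)(F)F)c1)C(=O)c1c(-c2ccccc2)c2cc(Cl)ccc2c(=O)n1C`: 3.4 nM
Compound 3 `COc1ccccc1CN(C)C(=O)c1c(-c2ccccc2)c2ccccc2c(=O)n1C`: 30 nM

In an assay on IM-9 cells for binding affinity to Substance-P receptor (Homo sapiens) (on this read-out higher numbers stand for weaker inhibition and lower numbers for stronger inhibition), compound 3 gives 30 nM, the highest of the three numbers. Its nearest neighbour is compound 1 with 19 nM, and the two lie within the usual scatter. Compound 2 with 3.4 nM sits clearly beyond it.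

Compound 4 `COc1ccccc1CN(C)C(=O)c1c(-c2ccccc2C)c2ccccc2c(=O)n1C` differs from compound 3 by methyl in place of hydrogen on an aromatic carbon, a methyl in place of hydrogen on an aromatic carbon. Within the data shown here, no measured pair isolates this change; compound 1 carries the same 2-methylphenyl but also a different benzyl group, so its value cannot be read as that step alone. A shift no larger than the scatter is expected, with a 1.5-fold lower number from compound 3 to compound 4 (0.18 log units; within the scatter) as the estimated step. Compound 4 is therefore estimated at 20 nM, in the range 8 nM to 50 nM.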

Compound 4, half-maximal inhibitory concentration: 16 nM
Compound 4: the middle estimate sits 1.3-fold (0.10 log units) above what was measured; the range from low to high includes it.
By their numbers in this assay, from the lowest: compound 2; then compounds 4, 1 and 3 (each within the scatter of the next).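

In this assay the change from phenyl to 2-methylphenyl can now be read alone: a 1.9-fold lower number from compound 3 to compound 4 (0.27 log units; within the scatter) lies within the scatter, so no effect of this methyl, on an aromatic carbon ortho to a large group, can be claimed. With the 2-methylphenyl held fixed, methoxy in place of chloro gives a 1.2-fold lower number from compound 1 to compound 4 (0.07 log units; within the scatter), also within the scatter. Nothing at hand bears on the reason for either result. As far as these compounds go, whether an ethyl group or an amine in place of this methyl would move the number beyond the scatter remains open.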